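A few compounds are considered here, and "the series" means these few. Any claim that something is new, unique, unknown or untested is made for them only; others in the source may bear on it.

Three compounds of the series carry a number in a functional assay on HeLa cells (Homo sapiens) for cytotoxicity, read by MTT assay, with a stated time of 48 h; a lower number here means a stronger inhibitor, a higher number a weaker inhibitor. Compound 1 `CC(C)=CCC/C(C)=C/CC/C(C)=C/CC[C@@H]1[C@@]2(C)CC/C(=N\OCc3cn(-c4cccc(O)c4)nn3)C(C)(C)[C@@H]2CC[C@@]1(C)O` gives 13500 nM. Compound 2 `CC(C)=CCC/C(C)=C/CC/C(C)=C/CC[C@@H]1[C@@]2(C)CC/C(=N\OCc3cn(-c4ccncc4)nn3)C(C)(C)[C@@H]2CC[C@@]1(C)O` gives 18800 nM; the step of a 1.4-fold higher number from compound 1 to compound 2 (0.14 log units; within the scatter) stays within the scatter. Compound 3 `CC(C)=CCC/C(C)=C/CC/C(C)=C/CC[C@@H]1[C@@]2(C)C/C(=C\c3ccc(OCc4cn(-c5ccccc5)nn4)cc3)C(=O)C(C)(C)[C@@H]2CC[C@@]1(C)O`, whose triazole-bearing side group is joined to the shared core in a different way, gives 36300 nM. That is the highest of the three numbers, but it sits within the scatter of compound 2 and beyond the scatter only against compound 1, so compound 3 can at most be called the weaker end of a narrow spread.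

Compound 4 `CC(C)=CCC/C(C)=C/CC/C(C)=C/CC[C@@H]1[C@@]2(C)C/C(=C\c3ccc(OCc4cn(-c5ccncc5)nn4)cc3)C(=O)C(C)(C)[C@@H]2CC[C@@]1(C)O` has not yet been measured. It differs from compound 3 in one place: pyridin-4-yl in place of phenyl on an aromatic nitrogen. Within the data shown here, the only measured step that bears on this change is a 1.4-fold higher number from compound 1 to compound 2 (0.14 log units; within the scatter), where pyridin-4-yl likewise entered on the aromatic nitrogen of the five-membered aromatic ring with 3 nitrogen, there in place of 3-hydroxyphenyl; it did not leave the scatter. Among the measured compounds shown here, no second example of a pyridin-4-yl entering exists, so the expectation rests on that single step and on the nearness of the three numbers. In this assay compound 4 is therefore expected to give about 40000 nM, within 20000 nM to 80000 nM. The step is estimated as a 1.1-fold higher number from compound 3 to compound 4 (0.04 log units; within the scatter), in either direction but not beyond the scatter.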

Compound 4, half-maximal inhibitory concentration: 77600 nM
Compound 4: middle estimate off by 1.9-fold (0.29 log units), on the low side; measured number inside the range.
By their numbers in this assay, from the lowest: compounds 1, 2 and 3 (each within the scatter of the next, the first and the last beyond it); then compound 4.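

In this assay, among these compounds, exchanging phenyl for pyridin-4-yl on the aromatic nitrogen of the triazole gives a 2.1-fold higher number from compound 3 to compound 4 (0.33 log units; beyond the scatter), the first step at this position to leave the scatter and one in the direction of a weaker inhibitor. The earlier step, a 1.4-fold higher number from compound 1 to compound 2 (0.14 log units; within the scatter), stayed within the scatter, but it replaced 3-hydroxyphenyl rather than phenyl and sits on a side group joined differently to the shared core, so the two steps do not isolate a single cause and the size of the new one remains modest. The change swaps one ring carbon for nitrogen and adds one hydrogen-bond acceptor, but no measurement available here explains the higher number.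

The compounds shown leave open whether the placement of the ring nitrogen matters, which pyridin-3-yl or pyridin-2-yl on the same aromatic nitrogen would address. They also leave open how an amine or a carboxylic acid on the phenyl ring would behave here, and whether phenyl and pyridin-4-yl would differ in the same way with the other connection to the core.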